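Working notes: 1,3-benzothiazol-2-yl for 1,3-benzoxazol-2-yl

A few compounds are considered here, and "the series" means these few. Any claim that something is new, unique, unknown or untested is made for them only; others in the source may bear on it.

Measured so far in a functional assay on A-431 cells (Homo sapiens) for inhibition, read by MTT assay, with a stated time of 72 h; on this read-out lower numbers stand for stronger inhibition and higher numbers for weaker inhibition:
compound 1 `COc1ccc(-c2nnc(SCCCN3CCN(c4nc5ccccc5o4)CC3)o2)cc1` gives 52700 nM
compound 2 `Clc1ccc(-c2nnc(SCCCN3CCN(c4nc5ccccc5o4)CC3)o2)cc1` gives 89600 nM
compound 3 `c1ccc(-c2nnc(SCCCN3CCN(c4nc5ccccc5o4)CC3)o2)cc1` gives 57600 nM

Compound 1 stands level with compound 2 and compound 3, as all three values lie within the scatter of one another and no order can be read among them. Compound 4 `COc1ccc(-c2nnc(SCCCN3CCN(c4nc5ccccc5s4)CC3)o2)cc1` keeps the core of compound 1 and differs in one place: 1,3-benzothiazol-2-yl in place of 1,3-benzoxazol-2-yl on an amine nitrogen in a ring. The measured steps are all exchanges on an aromatic carbon. Chloro in place of methoxy gives a 1.7-fold higher number from compound 1 to compound 2 (0.23 log units; within the scatter) and hydrogen in place of methoxy gives a 1.1-fold higher number from compound 1 to compound 3 (0.04 log units; within the scatter) while hydrogen in place of chloro gives a 1.6-fold lower number from compound 2 to compound 3 (0.19 log units; within the scatter) as the third step. Each lies within the scatter. None of them touches the 1,3-benzoxazol-2-yl group, so no measurement speaks directly to the new exchange, and the range has to stay wide. Taking compound 1 at 52700 nM as the anchor, no step beyond the scatter is expected in this assay and no direction is favoured. The estimated step is a 1.2-fold lower number from compound 1 to compound 4 (0.07 log units; within the scatter) and it remains an expectation. For compound 4 the expected value is 45000 nM (estimated range 15000 nM to 110000 nM).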

Compound 4, half-maximal inhibitory concentration: 56200 nM
Estimate against measurement, compound 4: 1.2-fold (0.10 log units) below, within the range that was stated.
By their numbers in this assay, from the lowest: compounds 1, 4, 3 and 2 (each within the scatter of the next).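

In this assay, 1,3-benzothiazol-2-yl in place of 1,3-benzoxazol-2-yl on an amine nitrogen in a ring gives the only step shown at this position (a 1.1-fold higher number from compound 1 to compound 4 (0.03 log units; within the scatter)), whereas the earlier steps were all exchanges on an aromatic carbon. The two groups have the same heavy-atom count and the same ring make-up, differing in sulfur for oxygen, and with the methoxy group held constant this single exchange stays within the scatter. This is one matched pair and supports no wider claim about the position, and no measurement beyond these numbers bears on the reason for the result.

Still open, on these data alone, is whether a group of a different kind on that ring nitrogen, such as a plain phenyl, a pyridin-2-yl or an acetyl, would move the number beyond the scatter in this assay. Also open, as far as these compounds go, is whether 1,3-benzothiazol-2-yl reads the same when the methoxy group of compound 4 gives way to the chloro of compound 2 or the hydrogen of compound 3.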